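From isopropyl to butyl on the shared core

This account rests on a few compounds, and the source may have more. Where it says the series, first, only, none or still open, it means among the compounds named here.

Measured in a functional assay on MDA-MB-435 cells (Homo sapiens) for inhibition, read by sulforhodamine B assay, with a stated time of 48 h; on this read-out lower numbers stand for an effect already at smaller amounts and higher numbers for an effect only at larger amounts of compound:
Compound 1 `CCCN(c1ccc(OC)cc1)c1ncnc2occ(C)c12`: 27.3 nM
Compound 2 `CCN(c1ccc(OC)cc1)c1ncnc2occ(C)c12`: 8.1 nM
Compound 3 `COc1ccc(N(c2ncnc3occ(C)c23)C(C)C)cc1`: 504 nM

Compound 3 stands highest of the three at 504 nM. Compound 4 `CCCCN(c1ccc(OC)cc1)c1ncnc2occ(C)c12` has butyl in place of isopropyl on a nitrogen on an aromatic ring. Two large steps show what isopropyl did: an 18-fold higher number from compound 1 to compound 3 (1.27 log units; beyond the scatter) and a 62-fold higher number from compound 2 to compound 3 (1.79 log units; beyond the scatter). Removing the branch should therefore recover much of that loss. The modest step of a 3.4-fold lower number from compound 1 to compound 2 (0.53 log units; beyond the scatter) shows the shorter chain giving the lower number, so butyl is expected to fall somewhat above compound 1. A large step is therefore expected in this assay, a 7.2-fold lower number from compound 3 to compound 4 (0.86 log units; beyond the scatter). For compound 4 the estimated value is 70 nM, with an expected range of 25 nM to 220 nM.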

Compound 4, half-maximal effective concentration: 100 nM
Estimate against measurement, compound 4: 1.4-fold (0.15 log units) below; the measured number falls inside the stated range.
By their numbers in this assay, from the lowest: compound 2; then compound 1; then compound 4; then compound 3.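

In this assay, the unbranched chain keeps raising the number as it grows to butyl (a 12-fold higher number from compound 2 to compound 4 (1.09 log units; beyond the scatter)) and (a 3.7-fold higher number from compound 1 to compound 4 (0.56 log units; beyond the scatter)). Butyl nonetheless gives a lower number than the branched isopropyl (a 5.0-fold lower number from compound 3 to compound 4 (0.70 log units; beyond the scatter)), so on this nitrogen the placing of a carbon counts as well as the chain length. A methyl in place of hydrogen costs far more on the carbon bound to the nitrogen than at the end of the chain: the same change on two cores in this assay, a 62-fold higher number (1.79 log units; beyond the scatter) from compound 2 to compound 3 and a 3.7-fold higher number (0.56 log units; beyond the scatter) from compound 1 to compound 4, 17-fold (1.23 log units) apart, beyond the scatter of two such steps.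

From the compounds shown here alone, whether a longer chain such as pentyl continues this rise remains open. So does how a chain ending in an amine or a carboxylic acid would read.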